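A few compounds are considered here, and "the series" means these few. Any claim that something is new, unique, unknown or untested is made for them only; others in the source may bear on it.

Values in a physicochemical assay for acid dissociation, read by spectrophotometry, are as follows:
- compound 1 (`CCOc1cc(CN2CCC(NC(=O)c3cncc(C)c3)CC2)cc(OCC)c1-c1ccc(F)cc1`) gives 7.69
- compound 2 (`CCOc1cc(CN2CCC(NC(=O)c3cncc(C)c3)CC2)cc(OCC)c1Cl`) gives 7.46

Among the compounds with values here, on these numbers compound 2 at 7.46 lies within the scatter of compound 1, and no other measured compound is available for comparison.

The next structure is compound 3 (`CCOc1cc(CN2CCC(NC(=O)c3cncc(C)c3)CC2)cc(OCC)c1F`), which has fluoro in place of chloro on an aromatic carbon of compound 2, ortho to two ethoxy groups and para to a large group: fluoro in place of chloro on an aromatic carbon.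

Within the data shown here, only one measured step bears on this change. It altered the same aromatic carbon, with chloro in place of 4-fluorophenyl, and amounts to a number 0.23 log units lower from compound 1 to compound 2 (within the scatter). Among the measured compounds shown here, a single step is thin evidence, and no measured pair yet compares fluoro with chloro directly. Even so, with that one exchange at this carbon staying inside the scatter, no shift beyond the scatter is expected in this assay for the smaller exchange of one single atom for another.

The expected step is a number 0.01 log units lower from compound 2 to compound 3 (within the scatter). For compound 3 the estimated value is 7.45, with an expected range from 7.15 to 7.75.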

Compound 3, acid dissociation constant: 7.7
Estimate against measurement, compound 3: 0.25 log units below; low and high end bracket the measured number.
By their numbers in this assay, from the lowest: compounds 2, 1 and 3 (each within the scatter of the next).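

In this assay, within the data shown here, the first direct comparison of fluoro with chloro on this aromatic carbon, ortho to two ethoxy groups and para to a large group, gives a number 0.24 log units higher from compound 2 to compound 3 (within the scatter). Fluoro in place of 4-fluorophenyl on the same carbon gives a number 0.01 log units higher from compound 1 to compound 3 (within the scatter), so with the earlier chloro exchange, every pair among the three substituents now has a measured step within the scatter, whether a single atom or a ring is exchanged. Nothing available bears on the reason for the size of these steps.

The compounds shown leave open whether an amine, a carboxylic acid or a nitrile on this aromatic carbon would give a step beyond the scatter in this assay, since the substituents covered so far are only chloro, fluoro and 4-fluorophenyl. Also open, on these data alone, is how this read-out responds to a change elsewhere on the shared core, such as methoxy in place of one ethoxy group, as both ethoxy groups and the rest of the core are the same in all three compounds.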